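The compounds below may be only part of what the source reports. "The series", "measured", "known", "first", "only" and "open" are said of these compounds alone.

Compound 1, `CC(=O)OC[C@H]1O[C@@H](n2cc(COC3=CC(=O)c4ccccc4C3=O)nn2)[C@H](OC(C)=O)[C@@H](OC(C)=O)[C@@H]1OC(C)=O`, was tested in a functional assay on MDA-MB-231 cells (Homo sapiens) for cytotoxicity, read by sulforhodamine B assay, with a stated time of 72 h (a lower number here means a stronger inhibitor, a higher number a weaker inhibitor), where compound 1 gives 14000 nM. Going by the values given here, its only measured companion is compound 2, `CC(=O)OC[C@H]1O[C@@H](n2cc(COC3=CC(=O)c4ccccc4C3=O)nn2)[C@H](OC(C)=O)[C@@H](OC(C)=O)[C@H]1OC(C)=O`, which in this assay gives 16700 nM. The step from one to the other, a 1.2-fold higher number from compound 1 to compound 2 (0.08 log units; within the scatter), is the whole of the information available: the two compounds have the same atoms and bonds and differ only in configuration as drawn (the fact that compounds 1 and 2 differ only in the configuration as drawn), and the number hardly moves. On the two numbers shown, compound 1 holds the lower one, though the gap to compound 2 lies within the scatter, so no order between them can be claimed.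

Compound 3, `CC(=O)N[C@@H]1[C@@H](OC(C)=O)[C@H](OC(C)=O)[C@@H](COC(C)=O)O[C@H]1n1cc(COC2=CC(=O)c3ccccc3C2=O)nn1`, carries the change (acetamido in place of acetoxy on a saturated ring carbon). Among the compounds with values here, no measured step touches that kind of replacement; the only step at hand, a 1.2-fold higher number from compound 1 to compound 2 (0.08 log units; within the scatter), concerns configuration and was within the scatter. With nothing in the measured pair pointing either way, compound 3 is expected to sit close to compound 1, with a step of a 1.1-fold higher number from compound 1 to compound 3 (0.03 log units; within the scatter) at most. The estimate for compound 3 in this assay is 15000 nM, with a range from 6000 nM to 40000 nM.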

Compound 3, half-maximal inhibitory concentration: > 50000 nM
Compound 3: only a limit was reported (the forecaster's own chance of this, stated with the estimate: 15%); middle value at least 3.3-fold (0.52 log units) from the limit.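

Placing acetamido in place of acetoxy on this saturated ring carbon, next to the ring atom that bears a large group, gives an at least 3.5-fold higher number from compound 1 to compound 3 (0.55 log units; beyond the scatter). Going by these compounds alone, this is the first step to lie beyond the scatter, whereas the change of configuration, a 1.2-fold higher number from compound 1 to compound 2 (0.08 log units; within the scatter), did not, so this position of the six-membered ring responds to a change of substituent even though acetoxy and acetamido hold the same number of heavy atoms. Compound 3 gives only a limit in this assay, > 50000 nM, and not a number, which leaves the full size of the step unknown: the limit of > 50000 nM in this assay, at which 1 of the 3 values shown sits.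

The compounds shown leave open whether the loss follows the acetamido group itself or would appear with any replacement of acetoxy here, such as a free amine, a hydroxyl or a longer chain such as propanamido. They also leave open whether the same exchange on the other saturated ring carbons that bear acetoxy would move the number in the same way.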